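The source may report more compounds than this note shows. Statements on the series, on what has been measured and on what is new or still open speak of the compounds shown alone.

Going by the values given here, in a functional assay on the whole organism for antagonist activity, with Mus musculus as the target (on this read-out higher numbers stand for an effect only at larger amounts of compound and lower numbers for an effect already at smaller amounts), compound 1 `CN1CCN(CC(=O)NCC(=O)N(C)c2ccc(Cl)cc2C(=O)c2ccccc2Cl)CC1` gives 59 mg/kg and compound 2 `CCN(CC)CC(=O)NCC(=O)N(C)c1ccc(Cl)cc1C(=O)c1ccccc1Cl` gives 2.2 mg/kg as the lower of the two numbers so far. Compound 3 `CN(C)CC(=O)NCC(=O)N(C)c1ccc(Cl)cc1C(=O)c1ccccc1Cl` keeps the shared core and differs from compound 2 in one end group (dimethylamino in place of diethylamino on a saturated chain carbon bound to a carbonyl carbon) where dimethylamino takes the place of diethylamino on a saturated chain carbon bound to a carbonyl carbon. Among the compounds with values here, only one measured step touches this place. That step (a 27-fold lower number from compound 1 to compound 2 (1.43 log units; beyond the scatter)) is large, and it exchanged the ring of 4-methylpiperazin-1-yl for the open chain of diethylamino. Unlike that step, the present change involves no ring, so a far smaller shift is expected in this assay, probably one within the scatter and with no firm direction. The estimated move (a 1.4-fold higher number from compound 2 to compound 3 (0.13 log units; within the scatter)) stays small. For compound 3 the estimated value is 3 mg/kg with a range from 0.8 mg/kg to 12 mg/kg as the likely span.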

Compound 3, dose for half-maximal effect: 2.6 mg/kg
Beside the measured number, compound 3's estimate is 1.2-fold (0.06 log units) above it; the measured number falls inside the stated range.
By their numbers in this assay, from the lowest: compounds 2 and 3 (each within the scatter of the next); then compound 1.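

Replacing diethylamino with dimethylamino on a saturated chain carbon bound to a carbonyl carbon makes no change that can be told from the scatter in this assay (a 1.2-fold higher number from compound 2 to compound 3 (0.07 log units; within the scatter)). The large gap seen earlier is therefore not specific to diethylamino, since dimethylamino also stands far from 4-methylpiperazin-1-yl (a 23-fold lower number from compound 1 to compound 3 (1.36 log units; beyond the scatter)). Nothing available explains the difference between these open-chain groups and the ring group.

Going by these compounds, it remains open whether a ring amine such as pyrrolidin-1-yl or piperidin-1-yl would give numbers like those of compound 2 and compound 3 or like that of compound 1. On these data alone, it is also open whether a longer chain such as dipropylamino, or a plain unsubstituted amine, would hold the number at the level of compound 2 and compound 3.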